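Solubility of a cyclohexyl for benzyl exchange on a shared core

This account rests on a few compounds, and the source may have more. Where it says the series, first, only, none or still open, it means among the compounds named here.

Measured compounds:
compound 1, `C=CC(=O)N1CCC[C@@H](N2C(=O)N(Cc3ccccc3)Cc3cnc(Nc4ccc(N5CCN(C)CC5)cc4OC)nc32)C1`, 142 ug/mL
compound 2, `C=CC(=O)N1CC[C@H](N2C(=O)N(Cc3ccccc3)Cc3cnc(Nc4ccc(N5CCN(C)CC5)cc4OC)nc32)C1`, 107 ug/mL

Of the compounds shown here, two have been measured in a physicochemical assay for solubility, read by HPLC, in phosphate buffer, measured as thermodynamic solubility, with a stated time of 24 h, at pH 6.8; a lower number here means a less soluble compound, a higher number a more soluble compound. Within the data shown here, compound 1 gives 142 ug/mL and compound 2 gives 107 ug/mL; the only measured step, a 1.3-fold lower number from compound 1 to compound 2 (0.12 log units; within the scatter), is within the scatter, so the two numbers cannot be ordered. Among the measured compounds shown here, compound 2 stands at the lower of the two numbers, with compound 1 as its only neighbour.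

Compound 3, `C=CC(=O)N1CC[C@H](N2C(=O)N(C3CCCCC3)Cc3cnc(Nc4ccc(N5CCN(C)CC5)cc4OC)nc32)C1`, differs from compound 2 in one place: cyclohexyl in place of benzyl on an amide-type nitrogen in a ring. For the measured compounds named here, no measured step bears on this change; the one step that exists, from a piperidinyl to a pyrrolidinyl substituent, touches a different position and was within the scatter, so it gives no guidance on the size or direction of this exchange. The expectation for compound 3 therefore rests on the value of compound 2 alone, with a range widened to admit a step beyond the scatter in either direction.

Compound 3 is expected to give 80 ug/mL, within 25 ug/mL to 220 ug/mL, which corresponds to an estimated step of a 1.3-fold lower number from compound 2 to compound 3 (0.13 log units; within the scatter) in this assay.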

Compound 3, solubility: 763 ug/mL
The estimate for compound 3 lay 9.5-fold (0.98 log units) below the measured number; measured number outside the range, above it.
By their numbers in this assay, from the lowest: compounds 2 and 1 (each within the scatter of the next); then compound 3.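

In this assay, among these compounds, cyclohexyl in place of benzyl on an amide-type nitrogen in a ring gives a 7.1-fold higher number from compound 2 to compound 3 (0.85 log units; beyond the scatter), the first step to lie beyond the scatter; the earlier step, which changed the ring of the 1-(vinylcarbonyl) substituent, stayed within it. The read-out therefore responds to what stands at this nitrogen, at least in this one pair, which carries the 1-(vinylcarbonyl)pyrrolidin-3-yl group. The step appears although neither group carries a hydrogen-bond donor, a hydrogen-bond acceptor or a net charge, so those counts do not separate the two; the groups differ in that one ring is aromatic and the other is not, and nothing measured here accounts for the size of the step.

A single pair cannot show whether the same exchange would hold with the 1-(vinylcarbonyl)piperidin-3-yl group of compound 1 on the shared core. It also leaves open how other groups at this nitrogen would read, such as a smaller cycloalkyl ring, an open-chain alkyl group, or a ring carrying an amine or a hydroxyl group.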